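Alkyne-linked uracil series: removing the aryl spacer

The source may report more compounds than this note shows. Statements on the series, on what has been measured and on what is new or still open speak of the compounds shown alone.

Compound 3 `CCCCCc1ccc(C#Cc2cn(C/C=C/CN3C(=O)c4ccccc4C3=O)c(=O)[nH]c2=O)cc1` gives 5600 nM in a functional assay on MCF7 cells (Homo sapiens) for antiproliferative activity, read by MTT assay, with a stated time of 3 days (on this read-out higher numbers stand for weaker inhibition and lower numbers for stronger inhibition), the lowest number of the three measured, though compound 2 `CCCCC#Cc1cn(C/C=C/CN2C(=O)c3ccccc3C2=O)c(=O)[nH]c1=O` at 8800 nM sits within the scatter of it; compound 1 `CCCCCCC#Cc1cn(C/C=C/CN2C(=O)c3ccccc3C2=O)c(=O)[nH]c1=O` at 24000 nM lies further off. Compound 4 `CCCCCC#Cc1cn(C/C=C/CN2C(=O)c3ccccc3C2=O)c(=O)[nH]c1=O` differs from compound 3 by pentyl in place of 4-pentylphenyl on a triple-bonded carbon. For the measured compounds named here, the steps that bear on this are a 1.6-fold lower number from compound 2 to compound 3 (0.20 log units; within the scatter) and a 4.3-fold lower number from compound 1 to compound 3 (0.63 log units; beyond the scatter), and pentyl falls between butyl and hexyl in chain length. Reversing those steps, compound 4 is expected to give a higher number in this assay, with the step estimated as a 2.5-fold higher number from compound 3 to compound 4 (0.40 log units; beyond the scatter). The estimate for compound 4 is 14000 nM, expected between 7000 nM and 30000 nM.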

Compound 4, half-maximal inhibitory concentration: 44000 nM
Estimate against measurement, compound 4: 3.1-fold (0.50 log units) below; measured number outside the range, above it.
By their numbers in this assay, from the lowest: compounds 3 and 2 (each within the scatter of the next); then compounds 1 and 4 (each within the scatter of the next).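

In this assay, pentyl in place of 4-pentylphenyl on the triple-bonded carbon gives a 7.9-fold higher number from compound 3 to compound 4 (0.90 log units; beyond the scatter), a larger loss than the butyl and hexyl compounds suggested. The straight chains do not follow chain length: a 5.0-fold higher number from compound 2 to compound 4 (0.70 log units; beyond the scatter), whereas a 1.8-fold higher number from compound 1 to compound 4 (0.26 log units; within the scatter) lies within the scatter. Compound 2 goes against any claim that the ring is needed, since its number stays within the scatter of the number for compound 3.

No measured evidence accounts for these steps. Going by these compounds, whether a longer chain than hexyl, or an amine at the chain end, would restore the lower numbers remains open.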